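The compounds below may be only part of what the source reports. "The series", "measured", "known", "first", "only" and "open" are said of these compounds alone.

Of the compounds shown here, three of one family have been tested in a functional assay on U-373MG ATCC cells (Homo sapiens) for inhibition, read by colorimetric assay and MTT assay, with a stated time of 72 h; on this read-out lower numbers stand for stronger inhibition and higher numbers for weaker inhibition. Compound 1, with the structure `COc1ccc(-c2cc(NC(=S)NNC(=O)c3ccc(C)cc3)cs2)cc1`, gives only a limit of the assay in this assay, > 100000 nM, and no number. Compound 2, `Cc1ccc(C(=O)NNC(=S)Nc2csc(-c3ccccc3)c2)cc1`, gives 62000 nM in this assay. Compound 3, `COc1cc(C(=O)NNC(=S)Nc2csc(-c3ccccc3)c2)cc(OC)c1OC`, gives 44000 nM in this assay, and its difference from the core of compound 1 is not broken down here.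

From compound 1 to compound 2 the change is hydrogen in place of methoxy on an aromatic carbon, and the step that went with it was an at least 1.6-fold lower number from compound 1 to compound 2 (0.20 log units; that floor lies within the scatter). The size of that step rests on (the limit of > 100000 nM in this assay, at which 1 of the 3 values shown sits), so the true size may be larger than the floor quoted.

Compound 4, `COc1cc(OC)cc(C(=O)NNC(=S)Nc2csc(-c3ccccc3)c2)c1`, has not yet been measured. It differs from compound 3 by hydrogen in place of methoxy on an aromatic carbon. Going by the values given here, this is the same kind of change as the one from compound 1 to compound 2, but the surroundings differ: in compound 3 the methoxy that leaves sits ortho to two methoxy groups as well as para to a large group, whereas in compound 1 it sits only para to a large group.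

Given that the one measured example of this change, from compound 1 to compound 2, moved the number by an at least 1.6-fold lower number from compound 1 to compound 2 (0.20 log units; that floor lies within the scatter), a similarly small step is expected from compound 3 to compound 4, estimated as a 1.1-fold lower number from compound 3 to compound 4 (0.04 log units; within the scatter). Compound 4 is thus expected to give about 40000 nM in this assay, with the estimate spanning from 15000 nM to 120000 nM.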

Compound 4, half-maximal inhibitory concentration: 40000 nM
For compound 4 middle estimate and measured number coincide at the digits printed; the range from low to high includes it.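

Replacing a methoxy group on an aromatic carbon with a hydrogen has now been seen on two cores in this assay, and the new case gives a 1.1-fold lower number from compound 3 to compound 4 (0.04 log units; within the scatter), so on this core the change leaves the number within the ordinary noise of the measurement. Set side by side, the two cases read: the same change on two cores in this assay, an at least 1.6-fold lower number (0.20 log units; that floor lies within the scatter) from compound 1 to compound 2 and a 1.1-fold lower number (0.04 log units; within the scatter) from compound 3 to compound 4; the limit leaves it open whether they differ Compound 1 gives > 100000 nM, which is a limit and not a number, so the step on the core of compound 1 is known only as a floor; the pair therefore shows no sign of a large effect on the core of compound 3, but it does not show that the change carries over from one core to the other with the same size.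

The compounds shown leave open whether a different group in the same place, such as an amine, a chlorine atom or a carboxylic acid, would move the number beyond the scatter on these cores. They also leave open what would happen if the two methoxy groups that remain on compound 4 were replaced by hydrogen as well.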